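A few compounds are considered here, and "the series" means these few. Any claim that something is new, unique, unknown or untested is made for them only; others in the source may bear on it.

Measured compounds in an assay on cells for agonist activity at ecdysone receptor (Bombyx mori), read by a luciferase reporter, with a stated time of 24 h; on this read-out higher numbers stand for an effect only at larger amounts of compound and lower numbers for an effect already at smaller amounts:
compound 1, `CC(C)(C)N(NC(=O)c1ccc(Cl)cc1)C(=O)c1ccccc1Cl`, gives 115 nM;
compound 2, `Cc1ccc(C(=O)NN(C(=O)c2cc(C)cc(C)c2)C(C)(C)C)cc1`, gives 12 nM;
compound 3, `Cc1cc(C)cc(C(=O)N(NC(=O)c2ccc(Cl)cc2)C(C)(C)C)c1`, gives 19.1 nM.

Compound 3 stands second highest of these three numbers. Its nearest neighbour is compound 2: a 1.6-fold higher number from compound 2 to compound 3 (0.20 log units; within the scatter). The furthest is compound 1: a 6.0-fold lower number from compound 1 to compound 3 (0.78 log units; beyond the scatter). Compound 4, `Cc1cc(C)cc(C(=O)N(NC(=O)CCC(C)C)C(C)(C)C)c1`, differs from compound 3 in one place: isopentyl in place of 4-chlorophenyl on a carbonyl carbon. Neither measured step bears directly on this: one swaps one aryl for another on the other carbonyl, the other swaps a single substituent on the ring that is now removed. From the compounds shown here alone, replacing a whole aromatic ring with a chain is untested here, so a step of a 79-fold higher number from compound 3 to compound 4 (1.90 log units; beyond the scatter) towards higher numbers is expected, with wide uncertainty. Compound 4 is estimated at 1500 nM, between 150 nM and 15000 nM.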

Compound 4, half-maximal effective concentration: 91.2 nM
For compound 4 the middle estimate is 16-fold (1.22 log units) above the measured one, and the stated range ends above it.
By their numbers in this assay, from the lowest: compounds 2 and 3 (each within the scatter of the next); then compounds 4 and 1 (each within the scatter of the next).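

In this assay, this carbonyl carbon is shown for the first time carrying a chain instead of an aromatic ring: isopentyl raises the number both in place of 4-chlorophenyl (a 4.8-fold higher number from compound 3 to compound 4 (0.68 log units; beyond the scatter)) and in place of 4-methylphenyl (a 7.6-fold higher number from compound 2 to compound 4 (0.88 log units; beyond the scatter)). Both steps are modest, so in these pairs the ring gives lower numbers, but compound 4 shows that activity does not depend on it. Nothing shown explains this difference.

Still open, from the compounds shown here alone, is whether a longer chain, a shorter chain such as ethyl, or a benzyl group would bring the number closer to those of the ring compounds. Also open, going by these compounds, is how an amine or a carboxylic acid at the end of the chain would change it.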